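A bromobenzyl ether after three assay limits

The compounds below may be only part of what the source reports. "The series", "measured", "known", "first", "only" and "open" are said of these compounds alone.

In a functional assay on RAW264.7 cells (Mus musculus) for inhibition, read by Griess assay, with stated times of 1 h and 24 h (a lower number here means a stronger inhibitor, a higher number a weaker inhibitor), compound 1 `CCC(C)Oc1ccc(C(O)C2OC(=O)c3c(OC)cc(OC)cc32)cc1` gives > 10000 nM, which is a limit and not a number. Compound 2 `CCOCCOc1ccc(C(O)C2OC(=O)c3c(OC)cc(OC)cc32)cc1` gives > 10000 nM, also a limit. Compound 3 `COc1cc(OC)c2c(c1)C(C(O)c1ccc(OCCOc3ccccc3)cc1)OC2=O` gives > 10000 nM, again a limit. Compound 3 therefore stands with the other two at the limit of > 10000 nM in this assay, at which 3 of the 3 values shown sit. Compound 4 `COc1cc(OC)c2c(c1)C(C(O)c1ccc(OCc3ccc(Br)cc3)cc1)OC2=O` carries 4-bromophenyl in place of phenoxymethyl on a saturated chain carbon bound to an oxygen on an aromatic ring. The nearest measured changes at this place are a step that the two limits leave unreadable from compound 1 to compound 3 and a step that the two limits leave unreadable from compound 2 to compound 3, and neither has a readable size, so they set no direction in this assay. The expected change is only loosely bounded: a number no higher from compound 3 to compound 4 (the limit leaves the size open). For compound 4 the estimated value is 10000 nM, with an expected range of 3000 nM to 30000 nM.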

Compound 4, half-maximal inhibitory concentration: 6530 nM
The estimate for compound 4 lay 1.5-fold (0.19 log units) above the measured number; the range from low to high includes it.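

Among these compounds, on the oxygen on the aromatic ring, 4-bromobenzyl is the first group here to give a number rather than a limit in this assay. The change reads as an at least 1.5-fold lower number from compound 3 to compound 4 (0.18 log units; that floor lies within the scatter), as an at least 1.5-fold lower number from compound 2 to compound 4 (0.18 log units; that floor lies within the scatter) and as an at least 1.5-fold lower number from compound 1 to compound 4 (0.18 log units; that floor lies within the scatter), so the true gaps may be larger, but only these floors can be stated. The steps among compound 1, compound 2 and compound 3 cannot be read; all three values are limits: the limit of > 10000 nM in this assay, at which 3 of the 4 values shown sit.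

On these data alone, whether the bromine itself matters remains open. A plain benzyl or 4-chlorobenzyl group on this oxygen could help to settle it.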